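This account rests on a few compounds, and the source may have more. Where it says the series, first, only, none or still open, it means among the compounds named here.

Compound 1 `CCCC(=O)OCSc1ccccc1C(=O)NCCCCCCC(N)=O` is the starting point of this step. In an ADME assay on CEM-SS cells (Homo sapiens) for cytotoxicity, read by XTT assay, with a stated time of 6 days (on this read-out lower numbers stand for higher toxicity in this test and higher numbers for lower toxicity in this test), compound 1 gives 10.4 uM, which is the lowest of the two single numbers shown; its nearest neighbour is compound 3 `CCCC(=O)OCSc1ccccc1C(=O)NCC(=O)OC`, which in this assay gives 27.3 uM, reached by a 2.6-fold higher number from compound 1 to compound 3 (0.42 log units; beyond the scatter). Compound 2 `CCCC(=O)OCSc1ccccc1C(=O)N[C@H]1CCC[C@@H]1C(N)=O` has no single number but two entries, (the several entries of compound 2 in this assay, 31.2 uM; 43.3 uM (2 entries)); in this assay compound 2 gives 31.2 uM; 43.3 uM (2 entries), both higher than compound 1. The change to compound 4 `CCCC(=O)OCSc1ccccc1C(=O)NCC(=O)NC(C)C` is isopropylcarbamoyl in place of 5-carbamoylpentyl on a saturated chain carbon bound to an amide-type nitrogen. Going by the values given here, only the step from compound 1 to compound 3 bears on it, and that step was modest. A number of similar size and direction is therefore expected for compound 4, an increase described by a 2.1-fold higher number from compound 1 to compound 4 (0.33 log units; beyond the scatter). The estimate for compound 4 in this assay is 22 uM, between 10 uM and 45 uM.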

Compound 4, half-maximal toxic concentration: 92 uM
For compound 4 the middle estimate is 4.2-fold (0.62 log units) below the measured one; the whole stated range lies below it.
By their numbers in this assay, from the lowest: compound 1; then compound 3; then compound 4.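

On a saturated chain carbon bound to an amide-type nitrogen, isopropylcarbamoyl in place of 5-carbamoylpentyl gives an 8.8-fold higher number from compound 1 to compound 4 (0.95 log units; beyond the scatter) in this assay for this change. Isopropylamino in place of methoxy on a carbonyl carbon gives a 3.4-fold higher number from compound 3 to compound 4 (0.53 log units; beyond the scatter) on top of that, so a change on the carbonyl carbon alone moves this read-out. Nothing shown bears on why the number moves.

Going by these compounds, whether a carboxylic acid, a dimethylamino group or a longer chain on that carbonyl carbon would move the number further remains open. So does whether compound 4's number would hold with a group other than butanoyloxymethyl on the sulfur.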